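The compounds below may be only part of what the source reports. "The series", "measured", "known", "first", "only" and "open" are said of these compounds alone.

Of the compounds shown here, three have been measured so far in an assay on isolated protein for inhibition of histone deacetylase 8 (Homo sapiens), read by fluorescence, with a stated time of 90 min; a lower number here means a stronger inhibitor, a higher number a weaker inhibitor. Compound 1 `Cc1cc2cc(NS(=O)(=O)Cc3ccc(C(=O)NO)cc3)ccc2n(C)c1=O` gives 360 nM. Among the measured compounds shown here, compound 3 `Cc1cc2cc(NS(=O)(=O)Cc3cccc(C(=O)NO)c3)ccc2n(C)c1=O`, which carries the hydroxycarbamoyl group at a different position of the same ring, gives 465 nM, a number that lies within the usual scatter of the one for compound 1. Compound 2 `Cc1cc2cc(NCc3cc(C(=O)NO)ccc3Cl)ccc2n(C)c1=O`, in which the sulfonamide link is replaced by an amine link and the benzene ring carries a chlorine, gives 3190 nM, which stands clearly apart from the other two. Compound 1 thus sits at the low end of the three numbers shown, without being separable from compound 3.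

The next compound, compound 4 `COc1cc(C(=O)NO)ccc1CS(=O)(=O)Nc1ccc2c(c1)cc(C)c(=O)n2C`, keeps the shared core and the sulfonamide link of compound 1 and differs from it in a single place: methoxy in place of hydrogen on an aromatic carbon. For the measured compounds named here, no pair of measured compounds shows the effect of this kind of change, so there is no measured step to lean on. Given that the hydroxycarbamoyl group and the link to the core are both unchanged, the step is expected to be small, in either direction or none beyond the scatter, a 1.3-fold higher number from compound 1 to compound 4 (0.10 log units; within the scatter). Compound 4 is therefore estimated at 450 nM in this assay, with a range from 180 nM to 1200 nM.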

Compound 4, half-maximal inhibitory concentration: 231 nM
Estimate against measurement, compound 4: 1.9-fold (0.29 log units) above; low and high end bracket the measured number.
By their numbers in this assay, from the lowest: compounds 4, 1 and 3 (each within the scatter of the next); then compound 2.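

In this assay there is a 1.6-fold lower number from compound 1 to compound 4 (0.19 log units; within the scatter) when methoxy takes the place of hydrogen on an aromatic carbon ortho to a large group and meta to a hydroxycarbamoyl group, so this position accepts the added methoxy without a step beyond the scatter. Among the compounds shown here, the earlier compounds held no pair differing in one place, and this single step is now the only direct reading of a change on this ring, for one group at one position. No measurement shown here addresses why the number stays within the scatter.

On these data alone, whether the same position would accept other groups, such as an amine, a carboxylic acid, a hydroxyl or a longer alkoxy chain, remains open, since a single methoxy says nothing about how far such tolerance extends. Also open, as far as these compounds go, is whether methoxy on other carbons of this ring, or on compound 3, which carries the hydroxycarbamoyl group at a different position of the same ring, would give a step of similar size.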